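Methoxymethyl on the chromone hydroxyl: antiproliferative series notes

This account rests on a few compounds, and the source may have more. Where it says the series, first, only, none or still open, it means among the compounds named here.

Measured so far:
compound 1 `CC/C=C\C/C=C\C/C=C\CCCCCCCc1cc(=O)c2c(O)cc(O)cc2o1` — 17500 nM
compound 2 `CC/C=C\C/C=C\C/C=C\CCCCCCCc1cc(=O)c2c(O)cc(OCOC)cc2o1` — 17500 nM
compound 3 `CC/C=C\C/C=C\C/C=C\CCCCCCCc1cc(=O)c2c(O)c(C)c(O)c(C)c2o1` — 17500 nM

All three are characterised in a functional assay on MCF7 cells (Homo sapiens) for antiproliferative activity, read by MTT assay; on this read-out lower numbers stand for stronger inhibition and higher numbers for weaker inhibition. Compound 1 gives 17500 nM. Compound 2 carries methoxymethyl in place of hydrogen on an oxygen on an aromatic ring and gives 17500 nM; the step of no change at the digits printed from compound 1 to compound 2 (within the scatter). Compound 3 gives 17500 nM, level with compounds 1 and 2; the difference between the core of compound 3 and the core of compound 1 is not broken down here.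

Compound 4 `CC/C=C\C/C=C\C/C=C\CCCCCCCc1cc(=O)c2c(O)c(C)c(OCOC)c(C)c2o1` is not yet measured. It differs from compound 3 by methoxymethyl in place of hydrogen on an oxygen on an aromatic ring. The two place lines read the same word for word, so this is the same change that was made from compound 1 to compound 2. In this assay that change produced no change within the scatter, and compound 3 sits at the same level as compound 1, so a step of about no change at the digits printed from compound 3 to compound 4 (within the scatter) is expected from compound 3 to compound 4, resting on no change at the digits printed from compound 1 to compound 2 (within the scatter). The estimate for compound 4 in this assay is 17500 nM, with a range of 8000 nM to 38000 nM expected to cover most repeats.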

Compound 4, half-maximal inhibitory concentration: > 84100 nM
Compound 4: only a limit was reported; the forecaster's own chance of this, stated with the estimate: 25%; middle value at least 4.8-fold (0.68 log units) from the limit.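

In this assay the change from hydroxy to methoxymethoxy gives an at least 4.8-fold higher number from compound 3 to compound 4 (0.68 log units; beyond the scatter), so the outcome seen on the core of compound 1 does not carry over to the core of compound 3: the same change on two cores in this assay, no change at the digits printed (within the scatter) from compound 1 to compound 2 and an at least 4.8-fold higher number (0.68 log units; beyond the scatter) from compound 3 to compound 4, at least 4.8-fold (0.68 log units) apart, beyond the scatter of two such steps

Compound 4 reads > 84100 nM, which is a limit of the assay and not a number, so the full size of this step stays unknown: the limit of > 84100 nM in this assay, at which 1 of the 4 values shown sits.

The result shows that, for these two pairs only, the same change gives a different outcome on the two cores; it does not show which part of the core of compound 3 accounts for that difference, and it supports no rule beyond the four compounds shown.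

Still open, on these data alone, is whether a simple methyl ether or an acetate on that oxygen would follow the methoxymethyl result on each core. Also open, as far as these compounds go, is whether a shorter saturated chain in place of the long unsaturated chain would leave the difference between the two cores intact.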